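The source may report more compounds than this note shows. Statements on the series, on what has been measured and on what is new or still open speak of the compounds shown alone.

Compound 1, `CN(C)C(=O)c1cc2cnc(Nc3ccc(S(=O)(=O)NCCCCCN=C=S)cc3)nc2n1C1CCCC1`, gives 102% in a functional assay on A549 cells (Homo sapiens) for inhibition, read by CCK-8 assay, with a stated time of 72 h, tested at 10 uM; a lower number here means a weaker effect, a higher number a stronger effect of the compound at the concentration tested. Compound 2, `CN(C)C(=O)c1cc2cnc(Nc3ccc(S(=O)(=O)NCCCCCCCN=C=S)cc3)nc2n1C1CCCC1`, gives 101% in this assay.

Compound 1 stands highest of the two numbers, though its nearest neighbour compound 2 sits a number 1 percentage points lower from compound 1 to compound 2 (within the scatter), so the two cannot be told apart. Compound 3, `CN(C)C(=O)c1cc2cnc(Nc3ccc(C(=O)NCCCCCN=C=S)cc3)nc2n1C1CCCC1`, differs from compound 1 by a group of 11 heavy atoms (7 carbon, 2 nitrogen, 1 oxygen, 1 sulfur; no ring) in place of a group of 12 heavy atoms (6 carbon, 2 nitrogen, 2 oxygen, 2 sulfur; no ring), on an aromatic carbon. Among the measured compounds shown here, no measured step touches this part of the molecule: the only step known, from compound 1 to compound 2, changes the chain carrying the isothiocyanate and leaves the sulfonamide in place, so it does not bear directly on the change to compound 3. With both measured compounds giving essentially complete inhibition, the chain is the only feature varied so far. Compound 3 is expected to remain near complete inhibition, with an estimated step of a number 7 percentage points lower from compound 1 to compound 3 (within the scatter), and an estimated value of 95%, ranging from 70% to 105%.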

Compound 3, a percentage reported as inhibition, at one concentration (the size of the read-out at that concentration, not a potency): 100%
Beside the measured number, compound 3's estimate is 5 percentage points below it; the range from low to high includes it.
By their numbers in this assay, from the lowest: compounds 3, 2 and 1 (each within the scatter of the next).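

Compounds 1 and 2 both carried the sulfonamide, so they said nothing about the link on the aromatic carbon para to a large group. Compound 3 now tests that link, with a carbonyl in place of the sulfonyl, and the step is a number 2 percentage points lower from compound 1 to compound 3 (within the scatter), so a sulfonyl at this position is not required for the high read-out in this assay at the single concentration tested. No available evidence bears on why the two links cannot be told apart.

All three compounds lie close to complete inhibition, so a single high concentration cannot show whether the carbonyl and sulfonyl links would differ at lower concentrations. The compounds shown also leave open what an amine in place of the isothiocyanate at the end of the chain, or a shorter chain, would give in this assay.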